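This account rests on a few compounds, and the source may have more. Where it says the series, first, only, none or still open, it means among the compounds named here.

Working notes on the series. In an ADME assay on microsomes from liver (Homo sapiens) for metabolic stability, read by LC-MS, with a stated time of 10 min (a lower number here means that less of the compound is left, a higher number that more of the compound is left), compound 1 (`CC(C)N1CCN(c2cccc3c2C[C@H](CN(C)[C@H]2CCCc4cccnc42)NC3)CC1`) gives 56.6% and compound 2 (`CN(C[C@H]1Cc2c(cccc2N2CCN3CCC[C@@H]3C2)CN1)[C@H]1CCCc2cccnc21`) gives 52.2%. For the measured compounds named here, these are the only two numbers so far, and they lie within the scatter of each other, so compound 1 stands level with its one neighbour.

Compound 3 (`CN(C[C@H]1Cc2c(cccc2N2CCN(c3ccccn3)CC2)CN1)[C@H]1CCCc2cccnc21`) keeps the core of compound 1 and changes one group: pyridin-2-yl in place of isopropyl on an amine nitrogen in a ring. In words, this is pyridin-2-yl in place of isopropyl on an amine nitrogen in a ring.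

Going by the values given here, only one measured step bears on this change: a number 4.4 percentage points lower from compound 1 to compound 2 (within the scatter). That step swaps one group for another of equal heavy-atom count and brings in no aromatic ring, so it is only a weak guide here. Among the compounds with values here, no measured compound carries an aromatic ring on this nitrogen, and the direction therefore remains uncertain. Within the data shown here, a moderate fall in this assay is expected, possibly larger than the one measured step, with a wide margin.

The expected step is a number 10.6 percentage points lower from compound 1 to compound 3 (beyond the scatter). For compound 3 the estimated value is 46%, with an expected range of 24% to 68%.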

Compound 3, percent of the compound remaining: 27.4%
Compound 3: the middle estimate sits 18.6 percentage points above what was measured; the range from low to high includes it.
By their numbers in this assay, from the lowest: compound 3; then compounds 2 and 1 (each within the scatter of the next).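

At the amine nitrogen in the six-membered non-aromatic ring with 2 nitrogen, the choice of group can move the read-out in this assay: pyridin-2-yl in place of isopropyl gives a number 29.2 percentage points lower from compound 1 to compound 3 (beyond the scatter) and so opens the first gap in the series that lies clearly outside the usual variation. For the compounds shown here, the one earlier step, a number 4.4 percentage points lower from compound 1 to compound 2 (within the scatter) and thus within the scatter, replaced the isopropyl piperazine unit with a fused group that has no aromatic ring, and it showed no such sensitivity at this place. The new step also differs from that earlier one in bringing an aromatic ring with one hetero atom onto this nitrogen, but no measurement at hand explains why the number falls.

With a single aromatic example, the compounds shown do not separate an effect of the ring nitrogen of pyridin-2-yl from that of an aromatic ring as such, and phenyl or pyrimidin-2-yl on the same nitrogen would bear directly on that question. Also open, on these data alone, is how a small non-aromatic group such as cyclopropyl or acetyl would compare with isopropyl here.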